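Replacing 1H-imidazol-1-yl with dimethylamino in compound 2

The source may hold more compounds than are shown below. What is called first, only, known or untested is meant among the compounds shown, and "the series" means these compounds.

Of the compounds shown here, three have been tested so far in a functional assay on the whole organism for agonist activity, with Mus musculus as the target; a higher number here means that more compound is needed for the effect, a lower number that less compound is needed. Compound 1 (`Cc1cncn1CC#CC(C)N1CCCC1=O`) gives > 100 mg/kg, which is a limit and not a number. Compound 2 (`CC1CCC(=O)N1CC#CCn1ccnc1`) gives > 100 mg/kg, also a limit. Compound 3 (`Cc1cncn1CC#CCN1C(=O)CCC1C`) gives > 100 mg/kg, again a limit. All the readings therefore stand at one place: the limit of > 100 mg/kg in this assay, at which 3 of the 3 values shown sit. Compound 2 thus has no exact number to start from.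

Compound 4 (`CC1CCC(=O)N1CC#CCN(C)C`) has not yet been measured. It differs from compound 2 by a single change: dimethylamino in place of 1H-imidazol-1-yl on a saturated chain carbon bound to a triple-bonded carbon. For the measured compounds named here, the only measured step that touches the leaving group is a step that the two limits leave unreadable from compound 2 to compound 3, and it gives no size to build on. Going by the values given here, no measured compound carries dimethylamino, so the data do not fix a direction. The estimated step is a number no higher from compound 2 to compound 4 (the limit leaves the size open), and this expectation is a loose one. A further limit in this assay seems more likely than a number. For compound 4 the estimated value is 100 mg/kg, with an expected range of 20 mg/kg to 200 mg/kg.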

Compound 4, dose for half-maximal effect: 1.7 mg/kg
Beside the measured number, compound 4's estimate is 59-fold (1.77 log units) above it, outside the stated range (below it).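

For the compounds shown here, the earlier compounds offered no number to work from, and the one step among them could not be read: the limit of > 100 mg/kg in this assay, at which 3 of the 4 values shown sit. In this assay, the change gives an at least 58-fold lower number from compound 2 to compound 4 (1.76 log units; beyond the scatter), so the group on a saturated chain carbon bound to a triple-bonded carbon can decide whether a measurable dose appears at all. Going by these compounds alone, compound 4 is the first compound here with an exact number, and it gives further changes at this place a starting point that a limit could not provide.

This single step replaces a five-membered aromatic ring with an open-chain group, so it cannot show which part of that swap matters. From the compounds shown here alone, how an open-chain diethylamino group or a ring amine such as pyrrolidin-1-yl would behave at this place remains open.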